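Swapping the benzyl ether for a prenyl ether

This account rests on a few compounds, and the source may have more. Where it says the series, first, only, none or still open, it means among the compounds named here.

The three measured compounds share one core and differ only in the group on the ether oxygen of the chromane. Compound 1 `C=CCOc1c(C)c(C)c2c(c1C)CCC(C)(COc1ccc(/C=C3\SC(=O)NC3=O)cc1)O2` gives 2% in a functional assay on MCF7 cells (Homo sapiens), tested at 7.5 uM (a higher number here means a weaker effect of the compound at the concentration tested, a lower number a stronger effect), compound 3 `Cc1c(C)c2c(c(C)c1OCc1ccccc1)CCC(C)(COc1ccc(/C=C3\SC(=O)NC3=O)cc1)O2` gives 12%, and compound 2 `CC(C)=CCOc1c(C)c(C)c2c(c1C)CCC(C)(COc1ccc(/C=C3\SC(=O)NC3=O)cc1F)O2` gives 64%. Compound 3 thus stands second highest of the three: it sits next to compound 1, the step of a number 10 percentage points higher from compound 1 to compound 3 (within the scatter) being within the scatter, and far from compound 2, whose number lies beyond the scatter above it.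

Compound 4 `CC(C)=CCOc1c(C)c(C)c2c(c1C)CCC(C)(COc1ccc(/C=C3\SC(=O)NC3=O)cc1)O2` is reached from compound 3 by the change (2-methylprop-1-en-1-yl in place of phenyl on a saturated chain carbon bound to an oxygen on an aromatic ring). Among the measured compounds shown here, the only measured step at this place, a number 10 percentage points higher from compound 1 to compound 3 (within the scatter), was within the scatter, so the chain end seems to matter little between compound 1 and compound 3. For the measured compounds named here, compound 2, which carries the same chain as compound 4 but also a fluorine, gives a much weaker effect; no single-point step links it to compound 4, so this is only a hint. He therefore expects a modest rise, a number 16 percentage points higher from compound 3 to compound 4 (beyond the scatter), and estimates for compound 4 a value of 28%, between 5% and 60%.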

Compound 4, a percentage reported as activity, at one concentration (the size of the read-out at that concentration, not a potency): 5%
Beside the measured number, compound 4's estimate is 23 percentage points above it, and the stated range covers the measured number.
By their numbers in this assay, from the lowest: compounds 1, 4 and 3 (each within the scatter of the next); then compound 2.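

In this assay the step of a number 7 percentage points lower from compound 3 to compound 4 (within the scatter) joins the step of a number 3 percentage points higher from compound 1 to compound 4 (within the scatter) in showing that 3-methylbut-2-en-1-yl, benzyl and the vinyl-ended chain of compound 1 cannot be told apart at this place, on a saturated chain carbon bound to an oxygen on an aromatic ring. With the 3-methylbut-2-en-1-yl chain held constant, the step of a number 59 percentage points lower from compound 2 to compound 4 (beyond the scatter) comes with hydrogen in place of fluoro on an aromatic carbon, so the weak effect of compound 2 goes with the fluoro and not with the chain. Nothing at hand explains either finding.

On these data alone, whether an amine, a carboxylic acid or a longer chain at this place would leave the read-out as flat remains open. So does whether fluoro has the same large effect alongside the benzyl ether of compound 3.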